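Triazole hydroxamates: ring-nitrogen aryl change from compound 2 to compound 4

This account rests on a few compounds, and the source may have more. Where it says the series, first, only, none or still open, it means among the compounds named here.

Measured compounds:
compound 1, `COc1ccc(-c2nc(CNc3ccc(C(=O)NO)cc3)n(-c3ccccc3)n2)cc1`: 77.6%
compound 2, `O=C(NO)c1ccc(NCc2nc(-c3ccccc3)nn2-c2ccccc2Cl)cc1`: 64.6%
compound 3, `O=C(O)c1ccc(NCc2nc(-c3ccccc3)nn2-c2ccccc2)cc1`: -0.4%

In an assay on Sf9 cells for inhibition of protein deacetylase HDAC6 (Homo sapiens), read by fluorescence, with a stated time of 40 min, tested at 100 nM (a higher number here means more inhibition at the concentration tested (going by the name of the read-out), a lower number less inhibition), compound 2 gives 64.6%, the second highest of the three numbers. Compound 1 stands above it, and the gap lies beyond the scatter. For the measured compounds named here, compound 3 stands far below it, also beyond the scatter; compound 3 carries a carboxylic acid where the other two carry a hydroxamic acid, and no compound with that acid shows measurable inhibition here.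

Compound 4, `O=C(NO)c1ccc(NCc2nc(-c3ccccc3)nn2-c2ccc(C(F)(F)F)cc2)cc1`, is not yet measured. Its difference from compound 2: 4-(trifluoromethyl)phenyl in place of 2-chlorophenyl on an aromatic nitrogen

Going by the values given here, no pair of measured compounds differs in one place only, so no measured step speaks directly to this change. Compound 1 carries an unsubstituted phenyl on that aromatic nitrogen and gives 77.6%, close to compound 2; the aryl on that nitrogen has so far moved the number only modestly. The step from compound 2 to compound 4 in this assay is therefore expected to be small, in either direction, and likely within the scatter: a number 1.4 percentage points higher from compound 2 to compound 4 (within the scatter). Compound 4 is expected to give about 66%, with a range from 45% to 82%.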

Compound 4, a percentage reported as inhibition, at one concentration (the size of the read-out at that concentration, not a potency): 38.9%
Estimate against measurement, compound 4: 27.1 percentage points above; measured number below the stated range.
By their numbers in this assay, from the lowest: compound 3; then compound 4; then compound 2; then compound 1.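

In this assay, for the compounds shown here, the aryl on the aromatic nitrogen turns out to be a position that matters: 4-(trifluoromethyl)phenyl in place of 2-chlorophenyl gives a number 25.7 percentage points lower from compound 2 to compound 4 (beyond the scatter), the first step that isolates this place. The hydroxamic acid and the rest of the structure stay the same across this step, so a change in this aryl alone is enough to move the number beyond the scatter. No measured property of either group bears on this drop, so the result stands without an explanation.

The step changes both the substituent and where it sits on the phenyl, so the compounds shown cannot separate these two changes. From the compounds shown here alone, how a nitrile or an amine on this phenyl would read remains open.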